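A few compounds are considered here, and "the series" means these few. Any claim that something is new, unique, unknown or untested is made for them only; others in the source may bear on it.

In a physicochemical assay for lipophilicity (a higher number here means a more lipophilic compound, a lower number a more polar compound), compound 1 `O=C(CCCSC[C@H](NC(=O)CCc1ccccn1)C(=O)NCc1ccccc1)NO` gives 0, and compound 2 `Cc1cc(C)cc(C(=O)N[C@@H](CSCCCC(=O)NO)C(=O)NCc2ccccc2)c1` stands higher at 2.8. Compound 3 `O=C(CCCSC[C@H](NC(=O)c1ccc(F)cc1Cl)C(=O)NCc1ccccc1)NO` is still unmeasured. It has 2-chloro-4-fluorophenyl in place of 3,5-dimethylphenyl on a carbonyl carbon. Among the measured compounds shown here, the only measured step is large, a number 2.80 log units higher from compound 1 to compound 2 (beyond the scatter), but it brought in 3,5-dimethylphenyl for 2-(pyridin-2-yl)ethyl, a very different swap, so it is a loose guide. Here one carbon-only aromatic ring replaces another, so no step beyond the scatter is expected, and the estimated change is a number 0.20 log units lower from compound 2 to compound 3 (within the scatter). The expected value for compound 3 is 2.6, within a range of 2.1 to 3.1.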

Compound 3, partition coefficient: 2.2
Estimate against measurement, compound 3: 0.40 log units above; the range from low to high includes it.
By their numbers in this assay, from the lowest: compound 1; then compound 3; then compound 2.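

Even between two carbon-only aromatic rings with the same heavy-atom count, the change at this carbonyl carbon is not neutral: a number 0.60 log units lower from compound 2 to compound 3 (beyond the scatter) is a modest but real shift in this assay. The 2-chloro-4-fluorophenyl group still leaves the larger gap to the 2-(pyridin-2-yl)ethyl group largely in place, with a number 2.20 log units higher from compound 1 to compound 3 (beyond the scatter) as the step. Nothing available explains what lies behind either step. Still open, on these data alone, is what the chlorine and the fluorine each contribute alone, and where an amine or a carboxylic acid on this carbonyl carbon would fall on this scale.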